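Ethyl on an amide-type nitrogen: compound 1 to compound 4

The source may report more compounds than this note shows. Statements on the series, on what has been measured and on what is new or still open speak of the compounds shown alone.

Compound 1 `O=C(CC(CC(=O)NC1Cc2ccccc2C1)c1ccccc1)NCCN1CCCCC1` gives only a limit in a functional assay on A549 cells (Homo sapiens) for inhibition; on this read-out lower numbers stand for stronger inhibition and higher numbers for weaker inhibition: compound 1 reads > 100000 nM, which is not a number. Compound 2 `O=C(CC(CC(=O)NC1Cc2ccccc2C1)c1ccccc1)NCCN1CCCC1` also gives only a limit, > 100000 nM. Compound 3 `Cc1ccc(C(CC(=O)NCCN2CCCCC2)CC(=O)NC2Cc3ccccc3C2)cc1` likewise gives only a limit, > 100000 nM. The measured set is thus summed up as the limit of > 100000 nM in this assay, at which 3 of the 3 values shown sit.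

The next structure, compound 4 `CCN(C(=O)CC(CC(=O)NCCN1CCCCC1)c1ccccc1)C1Cc2ccccc2C1`, carries ethyl in place of hydrogen on an amide-type nitrogen. Among the measured compounds shown here, two measured steps bear on it, though only loosely: a step that the two limits leave unreadable from compound 1 to compound 2, and a step that the two limits leave unreadable from compound 1 to compound 3. Neither has a readable size and neither changes that nitrogen, so the series offers no measured size for this change. No step beyond the scatter is expected in this assay, and another limit is the likeliest report. For compound 4 the estimated value is 100000 nM, with an expected range of 30000 nM to 300000 nM. The estimated step is a number no higher from compound 1 to compound 4 (the limit leaves the size open).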

Compound 4, half-maximal inhibitory concentration: 84500 nM
The estimate for compound 4 lay 1.2-fold (0.07 log units) above the measured number; measured number inside the range.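

With ethyl on the amide-type nitrogen whose other neighbours are the carbonyl carbon and a saturated ring carbon, the only compound shown that gives a number in this assay is compound 4, 84500 nM. As far as these compounds go, the step reads an at least 1.1-fold lower number from compound 1 to compound 4 (0.07 log units; that floor lies within the scatter), and its true size remains open, as one end of it is a limit. The other compounds give no number to compare with compound 4: the limit of > 100000 nM in this assay, at which 3 of the 4 values shown sit.

The steps from compound 1 to compound 2 and from compound 1 to compound 3 cannot be read, so the pyrrolidin-1-yl and methyl changes cannot be set against the ethyl change. Also open, from the compounds shown here alone, is whether methyl or a longer chain such as propyl on this nitrogen would give a number beyond the scatter from that of compound 4.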